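Pyridinyl for Imidazolyl: Expected Cytotoxicity of Compound 4

This account rests on a few compounds, and the source may have more. Where it says the series, first, only, none or still open, it means among the compounds named here.

Compound 1 `COC(=O)N[C@H](C(=O)NN(CCC[C@@](O)(Cc1ccccc1)C(=O)N[C@H]1c2ccccc2C[C@H]1O)Cc1ccc(Br)cc1)C(C)(C)C` gives > 10000 nM in an ADME assay on MT4 cells (Homo sapiens) for cytotoxicity (on this read-out lower numbers stand for higher toxicity in this test and higher numbers for lower toxicity in this test), which is a limit of the assay rather than a number.
Compound 2 `COC(=O)N[C@H](C(=O)NN(CCC[C@](O)(Cc1ccccc1)C(=O)N[C@H]1c2ccccc2C[C@H]1O)Cc1ccc(Br)cc1)C(C)(C)C` gives > 10000 nM in this assay, again a limit.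
Compound 3 `COC(=O)N[C@H](C(=O)NN(CCC[C@@](O)(Cc1ccccc1)C(=O)N[C@H]1c2ccccc2C[C@H]1O)Cc1ccc(-n2ccnc2)cc1)C(C)(C)C` gives > 10000 nM in this assay, also a limit.

Compound 3 therefore stands at the same limit as the other two measured compounds (the limit of > 10000 nM in this assay, at which 3 of the 3 values shown sit), so no ordering among them can be read. The step that the two limits leave unreadable from compound 1 to compound 2 cannot be sized, although compounds 1 and 2 differ only in the configuration as drawn (the fact that compounds 1 and 2 differ only in the configuration as drawn). The step that the two limits leave unreadable from compound 1 to compound 3 is likewise unreadable, because both ends sit at the limit (the limit of > 10000 nM in this assay, at which 3 of the 3 values shown sit).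

Compound 4 `COC(=O)N[C@H](C(=O)NN(CCC[C@@](O)(Cc1ccccc1)C(=O)N[C@H]1c2ccccc2C[C@H]1O)Cc1ccc(-c2ccncc2)cc1)C(C)(C)C` differs from compound 3 by pyridin-4-yl in place of 1H-imidazol-1-yl on an aromatic carbon. The measured step that bears on this position, from compound 1 to compound 3, gave no readable size, so no direction can be taken from it. The step that the limit leaves unreadable from compound 3 to compound 4 is therefore expected to be none beyond the scatter, with compound 4 most likely reported once more as a limit. Compound 4 is estimated at 20000 nM, in the range 7000 nM to 60000 nM.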

Compound 4, half-maximal cytotoxic concentration: > 10000 nM
Compound 4: a limit, no number (the forecaster's own chance of this, stated with the estimate: 85%); the middle value is on the limit's open side.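

Compound 4 gives > 10000 nM in this assay, which is again a limit, so no step from compound 1 or compound 3 to compound 4 can be read: the limit of > 10000 nM in this assay, at which 4 of the 4 values shown sit.

The compounds shown leave open how they rank against one another in this test, and whether exchanging the group on the aromatic ring changes the result at all.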